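Difluorophenyl Swap on an Azo Nitrogen: Cytotoxicity Expectation

The source may report more compounds than this note shows. Statements on the series, on what has been measured and on what is new or still open speak of the compounds shown alone.

Compound 1 `Fc1ccc(F)c(/N=N/c2ccc(NC[C@@H]3CCCN4CCCC[C@H]34)c3c2CCCC3)c1`: 40000 nM
Compound 2 `c1ccc(/N=N/c2ccc(NC[C@@H]3CCCN4CCCC[C@H]34)c3c2CCCC3)cc1`: 100000 nM
Compound 3 `CN(C)CCCN(/N=N/c1ccccc1)c1cccc(C(F)(F)F)c1`: 14000 nM

Of the compounds shown here, three have been tested in an ADME assay on MT4 cells (Homo sapiens) for cytotoxicity, read by MTT assay, with a stated time of 96 h; on this read-out higher numbers stand for lower toxicity in this test and lower numbers for higher toxicity in this test. Compound 2 gives 100000 nM, and compound 1 gives 40000 nM. Between them stands one change, (2,5-difluorophenyl in place of phenyl on a double-bonded nitrogen), and its step is a 2.5-fold lower number from compound 2 to compound 1 (0.40 log units; beyond the scatter). Compound 3, built on a different core, gives 14000 nM in this assay, the lowest of the three numbers; the difference between its core and that of compound 2 is not broken down here.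

Compound 4 `CN(C)CCCN(/N=N/c1cc(F)ccc1F)c1cccc(C(F)(F)F)c1` has not yet been measured. It arises from compound 3 by the same change, (2,5-difluorophenyl in place of phenyl on a double-bonded nitrogen), at the same place. Since this change lowered the number from compound 2 to compound 1 in this assay, a step of similar size is expected from compound 3 to compound 4, namely a 2.3-fold lower number from compound 3 to compound 4 (0.37 log units; beyond the scatter), though it rests on a single earlier pair on another core. Compound 4 is therefore estimated at 6000 nM in this assay, with a range from 2000 nM to 18000 nM.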

Compound 4, half-maximal cytotoxic concentration: 16000 nM
The estimate for compound 4 lay 2.7-fold (0.43 log units) below the measured number, within the range that was stated.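

In this assay, among the compounds shown here, placing 2,5-difluorophenyl in place of phenyl on the double-bonded nitrogen gives a 1.1-fold higher number from compound 3 to compound 4 (0.06 log units; within the scatter), so on this core the change leaves no step that can be read. The lowering seen on the core of compound 1 therefore did not carry over to the core of compound 3, and the two steps disagree: the same change on two cores in this assay, a 2.5-fold lower number (0.40 log units; beyond the scatter) from compound 2 to compound 1 and a 1.1-fold higher number (0.06 log units; within the scatter) from compound 3 to compound 4, 2.9-fold (0.46 log units) apart, beyond the scatter of two such steps. This shows that, across these two pairs, the effect of the change on this read-out cannot be taken from one core to the other, but with a single pair on each core it does not show which part of either core sets the difference, nor what a third core would do.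

The compounds shown leave open whether the dimethylamino group or the trifluoromethyl group of compound 3 has any part in this difference. They also leave open how a chlorophenyl or a methoxyphenyl group in the same place would read in this assay on either core.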